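Widening a Ring on a Shared Core

The source may hold more compounds than are shown below. What is called first, only, known or untested is meant among the compounds shown, and "the series" means these compounds.

Of the compounds shown here, three built on one shared core have been tested in a functional assay on MCF7 cells (Homo sapiens) for inhibition, read by sulforhodamine B assay, with a stated time of 48 h; on this read-out lower numbers stand for stronger inhibition of growth and higher numbers for weaker inhibition of growth. Compound 1 `O=C(CCl)NC(=O)Nc1ccc(OC2CCCCC2)cc1` gives 4700 nM in this assay. Compound 2 `O=C(CCl)NC(=O)Nc1cccc(OC2CCCCC2)c1` is made of the same atoms joined differently; the difference between the two cores is not broken down here. In this assay compound 2 gives 6300 nM, and compound 3 `O=C(CCl)NC(=O)Nc1ccc(OC2CCCCCC2)cc1` gives 3600 nM. Compound 3 differs from compound 1 by cycloheptyl in place of cyclohexyl on an oxygen on an aromatic ring. That change gave a 1.3-fold lower number from compound 1 to compound 3 (0.12 log units; within the scatter), so the two numbers cannot be told apart.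

Compound 4 `O=C(CCl)NC(=O)Nc1cccc(OC2CCCCCC2)c1` has not yet been measured. It differs from compound 2 by cycloheptyl in place of cyclohexyl on an oxygen on an aromatic ring. The place of the change reads the same word for word in both pairs, so this is the same change, seen twice among these compounds.

Compound 4 is expected to give about 5000 nM in this assay, with a likely range from 2500 nM to 10000 nM. Among the measured compounds shown here, that estimate means a 1.3-fold lower number from compound 2 to compound 4 (0.10 log units; within the scatter), chosen because a 1.3-fold lower number from compound 1 to compound 3 (0.12 log units; within the scatter) is the only earlier example of this change and it stayed within the scatter.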

Compound 4, concentration for 50% growth inhibition: 7200 nM
Compound 4: middle estimate off by 1.4-fold (0.16 log units), on the low side; low and high end bracket the measured number.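

Putting cycloheptyl in place of cyclohexyl on the core of compound 2 gave a 1.1-fold higher number from compound 2 to compound 4 (0.06 log units; within the scatter) in this assay, so these two numbers cannot be told apart. The same change on the core of compound 1 also stayed within the scatter, and the two steps agree with each other: the same change on two cores in this assay, a 1.3-fold lower number (0.12 log units; within the scatter) from compound 1 to compound 3 and a 1.1-fold higher number (0.06 log units; within the scatter) from compound 2 to compound 4, 1.5-fold (0.17 log units) apart, within the scatter of two such steps. This shows that the change carried over between these two cores without a step that can be read on either one, but it does not show that cycloheptyl strengthens or weakens growth inhibition, and two pairs say nothing firm about any other core.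

The compounds shown carry only cyclohexyl or cycloheptyl on the oxygen, so it remains open whether cyclopentyl, an open chain such as butyl, or a ring bearing an amine would give a step beyond the scatter. They also leave open whether the same result would hold outside this assay.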